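The compounds below may be only part of what the source reports. "The series", "measured", "known", "first", "only" and "open" are said of these compounds alone.

Measured compounds:
compound 1 `CN(c1cccnc1)c1cc(F)cc(-n2nnc(-c3ccccn3)n2)c1` — 22 nM
compound 2 `c1ccc(Oc2cccc(-n3nnc(-c4ccccn4)n3)c2)nc1` — 2860 nM

In a functional assay for antagonist activity at metabotropic glutamate receptor 5 (Homo sapiens) (a lower number here means a stronger inhibitor, a higher number a weaker inhibitor), compound 1 gives the lowest of the two numbers; compound 2 gives 2860 nM, a gap well beyond the scatter. Compound 3 `Fc1cc(-n2nnc(-c3ccccn3)n2)cc(-n2ccc3ccncc32)c1` is not yet measured. It differs from compound 1 as follows: a group of 9 heavy atoms (7 carbon, 2 nitrogen; one five-membered aromatic ring with 1 hetero atom, one six-membered aromatic ring with 1 hetero atom) in place of a group of 8 heavy atoms (6 carbon, 2 nitrogen; one six-membered aromatic ring with 1 hetero atom), on an aromatic carbon. Among the measured compounds shown here, no measured pair isolates this change, so the expected step rests on compound 1 alone; a modest loss, or none beyond the scatter, is expected, as a 2.7-fold higher number from compound 1 to compound 3 (0.44 log units; beyond the scatter). Compound 3 is accordingly estimated at 60 nM, with a range from 10 nM to 400 nM.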

Compound 3, half-maximal inhibitory concentration: 16 nM
For compound 3 the middle estimate is 3.8-fold (0.57 log units) above the measured one, within the range that was stated.
By their numbers in this assay, from the lowest: compounds 3 and 1 (each within the scatter of the next); then compound 2.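

In this assay, a group with one five-membered and one six-membered aromatic ring in place of methyl(pyridin-3-yl)amino gives a 1.4-fold lower number from compound 1 to compound 3 (0.14 log units; within the scatter). This position, meta to a fluoro group, therefore accepts a second kind of large group, and the methylamino link of compound 1 is not required. No available measurement bears on why the two groups read alike.

Going by these compounds, whether a morpholine or a plain phenyl would be accepted here remains open. On these data alone, the role of the fluoro group is also open, as is any exchange of it for a nitrile.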